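A chloro group on the phenyl ring of compound 1

This account rests on a few compounds, and the source may have more. Where it says the series, first, only, none or still open, it means among the compounds named here.

- compound 1 `COC(=O)N1N=C(c2ccccc2)CC1c1cc(OC)c(OC)c(OC)c1`: 1080 nM
- compound 2 `CCCOC(=O)N1N=C(c2ccccc2)CC1c1cc(OC)c(OC)c(OC)c1`: 14400 nM
- compound 3 `COC(=O)N1N=C(c2ccccc2)CC1c1ccc(OC)c(OC)c1`: 8940 nM

These values come from a functional assay on MDA-MB-231 cells (Homo sapiens) for antiproliferative activity, read by MTT assay, with a stated time of 48 h; a higher number here means a weaker inhibitor of growth, a lower number a stronger inhibitor of growth. In this small set compound 1, at 1080 nM, holds the lowest number, and its steps to the other two both lie beyond the scatter. The next compound, compound 4 `COC(=O)N1N=C(c2cccc(Cl)c2)CC1c1cc(OC)c(OC)c(OC)c1`, is still unmeasured. It takes compound 1 from phenyl to 3-chlorophenyl, with chloro in place of hydrogen on an aromatic carbon.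

Two measured steps start from compound 1, and neither touches this ring. With ethyl in place of hydrogen on a saturated chain carbon bound to an oxygen next to a carbonyl group, the result was a 13-fold higher number from compound 1 to compound 2 (1.12 log units; beyond the scatter). With hydrogen in place of methoxy on an aromatic carbon, it was an 8.3-fold higher number from compound 1 to compound 3 (0.92 log units; beyond the scatter). For the measured compounds named here, both changes raised the number, but they show only that compound 1 is sensitive at those two places. The data say nothing directly about a change on the phenyl ring, so their size does not carry over. A small drift towards a higher number is expected, on the weak ground that compound 1 is the lowest so far, and the estimated change is a 1.4-fold higher number from compound 1 to compound 4 (0.14 log units; within the scatter). For compound 4 the expected value is 1500 nM, with an estimated range from 450 nM to 5500 nM.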

Compound 4, concentration for 50% growth inhibition: 110 nM
Beside the measured number, compound 4's estimate is 14-fold (1.13 log units) above it; measured number outside the range, below it.
By their numbers in this assay, from the lowest: compound 4; then compound 1; then compounds 3 and 2 (each within the scatter of the next).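

In this assay, the phenyl ring of compound 1 proves to be a place where a single added chlorine atom lowers the number, as 3-chlorophenyl in place of phenyl gave a 9.8-fold lower number from compound 1 to compound 4 (0.99 log units; beyond the scatter) in this set. The earlier steps, a 13-fold higher number from compound 1 to compound 2 (1.12 log units; beyond the scatter) and an 8.3-fold higher number from compound 1 to compound 3 (0.92 log units; beyond the scatter), both went upward, so this is the first change shown that moves the number down, and it does so at a part of compound 1 that those steps left untouched. No measurement shown here explains the drop, so the result stands as an observation about this one change.

Still open, going by these compounds, is whether the drop belongs to chloro itself or would also follow from fluoro, methyl, methoxy or an amine on the same aromatic carbon, and whether chloro on another carbon of this ring would do the same. On these data alone, it is equally open whether chloro here would lower the number with the longer chain of compound 2 or the changed methoxy pattern of compound 3 in place.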